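Swapping the aryl group on the hydrazone carbon

This account rests on a few compounds, and the source may have more. Where it says the series, first, only, none or still open, it means among the compounds named here.

Going by the values given here, compound 3 `COc1ccc(/C=N/NC(=O)Nc2ccc(Oc3ccnc(-c4nncn4CCN(C)C)c3)c(F)c2)c(OC)c1` carries one of only two numbers recorded in an ADME assay on WI-38 cells (Homo sapiens) for cytotoxicity, read by MTT assay, with a stated time of 72 h; on this read-out lower numbers stand for stronger inhibition and higher numbers for weaker inhibition; in that assay compound 3 gives 6630 nM. The other number belongs to compound 1 `CN(C)CCn1cnnc1-c1cc(Oc2ccc(NC(=O)N/N=C/c3c[nH]c4ccccc34)cc2F)ccn1`, which gives 3620 nM, and the step of a 1.8-fold higher number from compound 1 to compound 3 (0.26 log units; within the scatter) stays within the scatter, so the two values cannot be told apart. Compound 2 `COc1ccc(OC)c(/C=N/NC(=O)Nc2ccc(Oc3ccnc(-c4nncn4CCN(C)C)c3)c(F)c2)c1` has no reported result in this assay, where compound 2 stands as "not determined" (no result reported). Compound 4 `CN(C)CCn1cnnc1-c1cc(Oc2ccc(NC(=O)N/N=C/c3ccc(O)c(Br)c3)cc2F)ccn1` arises from compound 3 through a single change: 3-bromo-4-hydroxyphenyl in place of 2,4-dimethoxyphenyl on a carbon with a double bond to nitrogen. Among the compounds with values here, the only measured step at that same position is a 1.8-fold higher number from compound 1 to compound 3 (0.26 log units; within the scatter), which did not rise above the scatter, and with that single comparison the expected step is a 1.2-fold lower number from compound 3 to compound 4 (0.08 log units; within the scatter), nothing beyond the scatter in either direction. Compound 4 is therefore estimated at 5500 nM, with a likely range from 2000 nM to 15000 nM.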

Compound 4, half-maximal inhibitory concentration: 5560 nM
Compound 4: middle estimate off by 1.0-fold (0.00 log units), on the low side, within the range that was stated.
By their numbers in this assay, from the lowest: compounds 1, 4 and 3 (each within the scatter of the next).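

In this assay, a third aryl group on the carbon with a double bond to nitrogen gives a 1.2-fold lower number from compound 3 to compound 4 (0.08 log units; within the scatter) and a 1.5-fold higher number from compound 1 to compound 4 (0.19 log units; within the scatter), both within the scatter. So 3-bromo-4-hydroxyphenyl, which brings a bromine and a hydrogen-bond donor, cannot be told apart from 2,4-dimethoxyphenyl or 1H-indol-3-yl here. Nothing available explains why these values sit so close. Still open, going by these compounds, is whether a group without an aromatic ring, such as cyclohexyl or a chain ending in an amine, would move the number beyond the scatter.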